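This account rests on a few compounds, and the source may have more. Where it says the series, first, only, none or still open, it means among the compounds named here.

Compound 1 `COc1ccc2nc(C)cc(OCC(=O)Nc3ccccc3)c2c1` in a toxicity assay on HepG2 cells (Homo sapiens) for inhibition, read by CellTiter-Glo, with a stated time of 48 h (on this read-out higher numbers stand for weaker inhibition and lower numbers for stronger inhibition), gives 39800 nM. Compound 2 `COc1ccc(NC(=O)COc2cc(C)nc3ccc(OC)cc23)cc1` reaches only a limit of the assay in this assay, > 100000 nM. Compound 3 `COc1ccc2nc(C)cc(OCC(=O)Nc3ccc(Cl)c(OC)c3)c2c1` likewise stops at a limit in this assay, > 100000 nM. The change methoxy in place of hydrogen on an aromatic carbon produced an at least 2.5-fold higher number from compound 1 to compound 2 (0.40 log units; beyond the scatter). The two cores differ by 4-chloro-3-methoxyphenyl in place of phenyl on an amide-type nitrogen, which gave an at least 2.5-fold higher number from compound 1 to compound 3 (0.40 log units; beyond the scatter). Both of those end points sit at the limit of > 100000 nM in this assay, at which 2 of the 3 values shown sit. Compound 4 `COc1ccc2nc(C)cc(OCC(=O)Nc3cc(OC)c(Cl)cc3OC)c2c1` is not yet measured; it differs from compound 3 by methoxy in place of hydrogen on an aromatic carbon, the same kind of change as before, though here the place is ortho to a large group, meta to a chloro group and para to a methoxy group rather than para to a large group. Because compound 3 already sits at the limit of > 100000 nM in this assay, at which 2 of the 3 values shown sit, the expected change is a step that the limit leaves unreadable from compound 3 to compound 4. For compound 4 the estimate in this assay is 150000 nM.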

Compound 4, half-maximal inhibitory concentration: > 100000 nM
Compound 4 was reported as a limit; the forecaster's own chance of this, stated with the estimate: 75%; the middle value does not contradict the limit.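

Among the compounds shown here, compound 3 and compound 4 both stop at a limit, so no step between them can be read in this assay: (the limit of > 100000 nM in this assay, at which 3 of the 4 values shown sit). Going by these compounds, how the added methoxy changes the true value stays open.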